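The source may hold more compounds than are shown below. What is called first, only, known or untested is meant among the compounds shown, and "the series" means these compounds.

Going by the values given here, in a functional assay on KG-1 cells (Homo sapiens) for antiproliferative activity, read by CCK-8 assay, with a stated time of 72 h (on this read-out higher numbers stand for weaker inhibition and lower numbers for stronger inhibition), compound 1 `COc1ccc(F)c(-c2ccc3c(NC(=O)c4ccc(N(C)CCN(C)C)cc4)n[nH]c3c2)c1F` gives 333 nM, the only actual number among the three values shown; the remaining values lie at the limit of > 1000 nM in this assay, at which 2 of the 3 values shown sit. Compound 2 `CCN1CCN(c2ccc(C(=O)Nc3n[nH]c4cc(-c5c(F)cc(F)c(OC)c5F)ccc34)cc2)CC1` is reported in this assay only as a limit, > 1000 nM. Compound 3 `CCN1CCN(c2ccc(C(=O)Nc3n[nH]c4cc(-c5cccc(OC)c5F)cc(F)c34)cc2)CC1` likewise reaches only a limit, > 1000 nM. Compound 4 `COc1ccc(F)c(-c2ccc3c(NC(=O)c4ccc(N5CCN(C(C)=O)CC5)cc4)n[nH]c3c2)c1F` has not yet been measured. It differs from compound 1 by 4-acetylpiperazin-1-yl in place of (2-(dimethylamino)ethyl)(methyl)amino on an aromatic carbon. Among the compounds with values here, no measured pair shows this exact change. Compound 2 and compound 3 each carry a piperazine and stop at a limit. The step of a 2.0-fold higher number from compound 1 to compound 4 (0.29 log units; within the scatter) is therefore expected to run toward weaker inhibition, of modest size. Compound 4 is estimated to give about 650 nM, within 220 nM to 2000 nM.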

Compound 4, half-maximal inhibitory concentration: 595 nM
Compound 4: middle estimate off by 1.1-fold (0.04 log units), on the high side; the range from low to high includes it.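

In this assay, 4-acetylpiperazin-1-yl in place of (2-(dimethylamino)ethyl)(methyl)amino gives a 1.8-fold higher number from compound 1 to compound 4 (0.25 log units; within the scatter). At this place, on an aromatic carbon para to a large group, the open chain and the six-membered non-aromatic ring therefore read alike on the shared core. Compound 4 also shows that a piperazine-bearing compound can give an actual number here.

From the compounds shown here alone, whether an unsubstituted piperazine or a morpholine at this place would read the same stays open. Changes elsewhere on the core cannot be read from these values: the limit of > 1000 nM in this assay, at which 2 of the 4 values shown sit.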